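This account rests on a few compounds, and the source may have more. Where it says the series, first, only, none or still open, it means among the compounds named here.

In a functional assay on A549 cells (Homo sapiens) for inhibition, read by CCK-8 assay, with a stated time of 72 h, tested at 1 uM (on this read-out higher numbers stand for more inhibition of growth at the one concentration tested and lower numbers for less inhibition of growth), compound 1 `CN(C)C(=O)c1cc2cnc(Nc3ccc(NC(=O)C4(C(=O)Nc5cccc(C#N)c5)CC4)cc3)nc2n1C1CCCC1` gives 70.8% and compound 2 `COC(=O)c1cccc(NC(=O)C2(C(=O)Nc3ccc(Nc4ncc5cc(C(=O)N(C)C)n(C6CCCC6)c5n4)cc3)CC2)c1` gives 10.5%, the lower of the two numbers. Compound 3 `COc1cccc(NC(=O)C2(C(=O)Nc3ccc(Nc4ncc5cc(C(=O)N(C)C)n(C6CCCC6)c5n4)cc3)CC2)c1` carries methoxy in place of the methoxycarbonyl of compound 2: methoxy in place of methoxycarbonyl on an aromatic carbon. Within the data shown here, one measured step bears on this change, a number 60.3 percentage points lower from compound 1 to compound 2 (beyond the scatter), which is large and also concerns the methoxycarbonyl group. Among the measured compounds shown here, with only that step to go on, a moderate to large rise in this assay is expected, though its size is poorly constrained. The expected change is a number 21.5 percentage points higher from compound 2 to compound 3 (beyond the scatter). The estimate for compound 3 is 32%, with an expected range of 8% to 65%.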

Compound 3, percent growth inhibition at one concentration: 77.2%
Compound 3: the middle estimate sits 45.2 percentage points below what was measured, outside the stated range (above it).
By their numbers in this assay, from the lowest: compound 2; then compounds 1 and 3 (each within the scatter of the next).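

In this assay, methoxy in place of methoxycarbonyl on the aromatic carbon gives a number 66.7 percentage points higher from compound 2 to compound 3 (beyond the scatter), so this position is not closed to substitution in general. Methoxy in place of cyano gives a number 6.4 percentage points higher from compound 1 to compound 3 (within the scatter), which leaves these two groups indistinguishable here; among the three groups, only methoxycarbonyl stands apart. No measurement available bears on the reason for this difference.

From the compounds shown here alone, whether a carboxylic acid or a primary amide at this position tracks methoxycarbonyl remains open. Also open, going by these compounds, is whether an amine or a longer chain such as ethoxy tracks methoxy.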